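The source may hold more compounds than are shown below. What is called first, only, known or untested is meant among the compounds shown, and "the series" means these compounds.

In an ADME assay on microsomes from liver (Macaca fascicularis) for metabolic stability, read by LC-MS, with a stated time of 65 min, tested at 1 uM (on this read-out lower numbers stand for a less stable compound and higher numbers for a more stable compound), compound 1 `CC(C)c1ncncc1-c1nc2cc(F)c(F)cc2n1C1CC1` gives 80%, the second highest of three numbers. Compound 2 `N#Cc1ncncc1-c1nc2cc(F)c(F)cc2n1C1CC1` gives 85%, which is a number 5 percentage points higher from compound 1 to compound 2 (within the scatter). Compound 3 `CN(C)c1ncncc1-c1nc2cc(F)c(F)cc2n1C1CC1` gives 6%, which is a number 74 percentage points lower from compound 1 to compound 3 (beyond the scatter). Still unmeasured, compound 4 `Fc1cc2nc(-c3cncnc3NCCC(F)(F)F)n(C3CC3)c2cc1F` carries (3,3,3-trifluoropropyl)amino in place of isopropyl on an aromatic carbon, ((3,3,3-trifluoropropyl)amino in place of isopropyl on an aromatic carbon). Going by the values given here, the nearest precedent is the large step to dimethylamino in compound 3, a number 74 percentage points lower from compound 1 to compound 3 (beyond the scatter), whereas the cyano step says little about an amino group. Among the compounds with values here, no measured compound carries this particular amino group, so only part of that large step is expected to carry over. The estimated change is a number 40 percentage points lower from compound 1 to compound 4 (beyond the scatter), a drop beyond the scatter. Compound 4 is expected near 40%, with an estimated range of 12% to 75%.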

Compound 4, percent of the compound remaining: 55%
Compound 4: middle estimate off by 15 percentage points, on the low side; the range from low to high includes it.
By their numbers in this assay, from the lowest: compound 3; then compound 4; then compounds 1 and 2 (each within the scatter of the next).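

In this assay, the position does not respond to every amino group alike: a number 49 percentage points higher from compound 3 to compound 4 (beyond the scatter), so the large loss seen with dimethylamino does not apply to all nitrogen-linked groups here. Even so, (3,3,3-trifluoropropyl)amino remains less favourable than either carbon-linked group, with a number 25 percentage points lower from compound 1 to compound 4 (beyond the scatter) and a number 30 percentage points lower from compound 2 to compound 4 (beyond the scatter). Nothing available explains the gap between the two amino groups. The compounds shown leave open whether the fluorines, the chain or the hydrogen on the nitrogen separates compound 4 from compound 3. Propylamino, methylamino and a cyclic amine such as morpholine would each help to settle this.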